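The source may hold more compounds than are shown below. What is called first, only, known or untested is meant among the compounds shown, and "the series" means these compounds.

Measured compounds:
- compound 1, `NC1=N[C@@H](COCc2ccccc2)CO1`: 360 nM
- compound 2, `CCN(C[C@@H]1COC(N)=N1)c1ccccc1`: 230 nM
- compound 3, `NC1=N[C@@H](c2ccc(Cl)c(Cl)c2)CO1`: 31 nM

In a functional assay on HEK293 cells for agonist activity at trace amine-associated receptor 1 (Homo sapiens), read by cAMP accumulation, with a stated time of 30 min (a lower number here means that less compound is needed, a higher number that more compound is needed for the effect), compound 2 gives 230 nM, the second highest of the three numbers. Compound 1 lies nearest to it, and the two values fall within the usual scatter of each other, so nothing separates them. Compound 3, with 31 nM, sits at a clearly lower number, beyond the scatter.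

Compound 4, `CCN(C[C@H]1COC(N)=N1)c1ccccc1`, is the mirror form of compound 2: the two compounds have the same atoms and bonds and differ only in configuration as drawn: 1 of 1 stereo elements differ; a stereocentre at a saturated ring carbon is drawn R in compound 2 and S in compound 4. No other pair among the measured compounds shows such a flip of configuration, so the shown data give no measured step to lean on.

With the benefit of doubt removed, such a change is expected to move this assay toward a higher number for compound 4, beyond the scatter rather than inside it, since the inverted form of a compound of this kind usually needs more to act. The expected step of a 3.5-fold higher number from compound 2 to compound 4 (0.54 log units; beyond the scatter) carries wide uncertainty. For compound 4 in this assay the estimate is 800 nM, with a range from 150 nM to 5000 nM.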

Compound 4, half-maximal effective concentration: 59 nM
For compound 4 the middle estimate is 14-fold (1.13 log units) above the measured one; measured number below the stated range.
By their numbers in this assay, from the lowest: compounds 3 and 4 (each within the scatter of the next); then compounds 2 and 1 (each within the scatter of the next).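

Inverting the stereocentre at the saturated ring carbon gives, in this assay, a 3.9-fold lower number from compound 2 to compound 4 (0.59 log units; beyond the scatter), so this position responds to configuration alone, and the form drawn S is the one that needs less compound. Within the data shown here, no earlier pair differed in one place only, which makes this the first step that can be read directly, though it rests on a single pair. The gap can be assigned to the stereocentre and to nothing else in the structure because of one fact: the fact that compounds 2 and 4 differ only in the configuration as drawn.

From the compounds shown here alone, whether the same inversion would lower the number in compound 1 or compound 3 remains open. Also open, going by these compounds, is whether this preference for the S form would persist if a longer chain or a carboxylic acid took the place of the ethyl group of compound 4.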